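Changing the benzyl group of compound 2

This account rests on a few compounds, and the source may have more. Where it says the series, first, only, none or still open, it means among the compounds named here.

Measured in a functional assay on MDA-MB-231 cells (Homo sapiens) for cytotoxicity, read by MTT assay, with a stated time of 72 h; a higher number here means a weaker inhibitor, a lower number a stronger inhibitor:
- compound 1 `CCN(CC)Cc1ccc2nc(NC(=O)N/N=C/c3cn(Cc4ccc(C(C)(C)C)cc4)c4ccccc34)sc2c1`: 2120 nM
- compound 2 `CN(C)Cc1ccc2nc(NC(=O)N/N=C/c3cn(Cc4ccc(C(C)(C)C)cc4)c4ccccc34)sc2c1`: 2230 nM
- compound 3 `CC1CCN(Cc2ccc3nc(NC(=O)N/N=C/c4cn(Cc5ccccc5)c5ccccc45)sc3c2)CC1`: 2850 nM

Compound 2 gives 2230 nM, which lies within the scatter of both other compounds, so the three numbers cannot be ranked. Compound 4 `CN(C)Cc1ccc2nc(NC(=O)N/N=C/c3cn(Cc4ccc(Cl)c(Cl)c4)c4ccccc34)sc2c1` carries 3,4-dichlorophenyl in place of 4-(tert-butyl)phenyl on a saturated chain carbon bound to an aromatic nitrogen. Within the data shown here, the only measured step, a 1.1-fold higher number from compound 1 to compound 2 (0.02 log units; within the scatter), concerns a different place, the swap of diethylamino for dimethylamino, so it offers only indirect guidance. Among the measured compounds shown here, no measured step covers this change, and no shift beyond the scatter is expected in this assay. The expected step is a 1.1-fold lower number from compound 2 to compound 4 (0.05 log units; within the scatter). Compound 4 is estimated at 2000 nM, with an expected range of 900 nM to 4500 nM.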

Compound 4, half-maximal inhibitory concentration: 1000 nM
Estimate against measurement, compound 4: 2.0-fold (0.30 log units) above; low and high end bracket the measured number.
By their numbers in this assay, from the lowest: compound 4; then compounds 1, 2 and 3 (each within the scatter of the next).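

In this assay, among these compounds, the substituent on the saturated chain carbon bound to an aromatic nitrogen is the first place here where a single change moves the number beyond the scatter: 3,4-dichlorophenyl in place of 4-(tert-butyl)phenyl gives a 2.2-fold lower number from compound 2 to compound 4 (0.35 log units; beyond the scatter) and so marks this position as responsive, unlike the amine swap at the other end of the molecule. Nothing available explains this shift.

The compounds shown leave open whether a single chlorine or a methoxy group on the benzyl ring would act in the same way. From the compounds shown here alone, it also remains open whether diethylamino in place of dimethylamino would still leave the number unchanged alongside 3,4-dichlorobenzyl.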